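Swapping 4-fluorophenyl for (pyridin-4-yl)methyl on a shared core

The source may report more compounds than this note shows. Statements on the series, on what has been measured and on what is new or still open speak of the compounds shown alone.

In a functional assay on HCT-116 cells (Homo sapiens) for cytotoxicity, read by CellTiter-Glo, with a stated time of 5 days (on this read-out higher numbers stand for weaker inhibition and lower numbers for stronger inhibition), compound 1 `Cc1cc(Nc2nn(-c3ccc(F)cc3)c(=O)c3ccccc23)n[nH]1` gives 800 nM. Going by the values given here, this is the only number available so far, so compound 1 cannot yet be ranked against any other compound. A close relative, compound 2 `Cc1ccc(-n2nc(Nc3cc[nH]n3)c3ccccc3c2=O)cc1`, reads "not determined" (no result reported) and offers no comparison.

The next molecule is compound 3 `Cc1cc(Nc2nn(Cc3ccncc3)c(=O)c3ccccc23)n[nH]1`. It keeps the core of compound 1 and changes a single place, an aromatic nitrogen of a six-membered aromatic ring, where (pyridin-4-yl)methyl stands in place of 4-fluorophenyl ((pyridin-4-yl)methyl in place of 4-fluorophenyl on an aromatic nitrogen). The two groups are equal in size by heavy-atom count, but the incoming group brings a hydrogen-bond acceptor that the outgoing one lacks.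

Among the compounds with values here, no measured pair shows what a change at this place does in this assay, so any forecast here is loose. Starting from compound 1 at 800 nM, a modest loss of strength is the cautious expectation, though little change cannot be ruled out. The expected step is a 1.9-fold higher number from compound 1 to compound 3 (0.27 log units; within the scatter). For compound 3, the estimated value is 1500 nM, with an expected range from 350 nM to 7000 nM.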

Compound 3, half-maximal inhibitory concentration: 20200 nM
For compound 3 the middle estimate is 13-fold (1.13 log units) below the measured one, outside the stated range (above it).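

Swapping 4-fluorophenyl for (pyridin-4-yl)methyl on the aromatic nitrogen gives this assay a clear shift toward weaker inhibition, with a 25-fold higher number from compound 1 to compound 3 (1.40 log units; beyond the scatter) and no other change to the molecule. Going by these compounds alone, this is the first sign that the read-out is sensitive to the group at this place, at least for this one pair. Matching heavy-atom counts and the absence of a net charge on either group did not make the two groups interchangeable, and no supporting data are available to explain the change.

The swap alters two things together, since the incoming group has a ring nitrogen and also a methyl part that links its ring to the shared core, so this single pair cannot show which of the two goes with the weaker inhibition. A benzyl group at this place would keep the methyl part without the ring nitrogen, while pyridin-4-yl would keep the ring nitrogen without the methyl part, so these two groups would be needed to separate the effects.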